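The source may report more compounds than this note shows. Statements on the series, on what has been measured and on what is new or still open speak of the compounds shown alone.

In a functional assay on HepG2 cells (Homo sapiens) for antiproliferative activity, read by XTT assay, with a stated time of 72 h (a lower number here means a stronger inhibitor, a higher number a weaker inhibitor), compound 1 `O=c1[nH]cnc2c1c(-c1ccoc1)cn2[C@@H]1O[C@H](CO)[C@@H](O)[C@H]1O` gives 12100 nM. Compound 2 `COc1ncnc2c1c(-c1ccoc1)cn2[C@@H]1O[C@H](CO)[C@@H](O)[C@H]1O` keeps the furan-3-yl group on a different core; how the two cores differ is not broken down here. In this assay compound 2 gives 290 nM, the lowest of the two numbers recorded. Compound 3 `O=c1[nH]cnc2c1c(-c1cccs1)cn2[C@@H]1O[C@H](CO)[C@@H](O)[C@H]1O` carries the change (thiophen-2-yl in place of furan-3-yl on an aromatic carbon). In this assay compound 3 returns only a limit, > 20000 nM. That change gave an at least 1.6-fold higher number from compound 1 to compound 3 (0.21 log units; that floor lies within the scatter), a floor set by the limit of > 20000 nM in this assay, at which 1 of the 3 values shown sits. Compound 4 `COc1ncnc2c1c(-c1cccs1)cn2[C@@H]1O[C@H](CO)[C@@H](O)[C@H]1O` carries the same change from compound 2: thiophen-2-yl in place of furan-3-yl on an aromatic carbon. For compound 4 the expected step is a 3.1-fold higher number from compound 2 to compound 4 (0.49 log units; beyond the scatter), larger than the floor seen earlier because compound 3 stopped at the limit of > 20000 nM in this assay, at which 1 of the 3 values shown sits, and the true size is hidden. Compound 4 is therefore estimated at 900 nM, between 250 nM and 4000 nM.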

Compound 4, half-maximal inhibitory concentration: 13900 nM
The estimate for compound 4 lay 15-fold (1.19 log units) below the measured number; measured number above the stated range.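

In this assay, thiophen-2-yl in place of furan-3-yl on the core of compound 2 gave a 48-fold higher number from compound 2 to compound 4 (1.68 log units; beyond the scatter), a large step. Set beside the same change on the core of compound 1, this does not establish whether the core alters the size of the step: the same change on two cores in this assay, an at least 1.6-fold higher number (0.21 log units; that floor lies within the scatter) from compound 1 to compound 3 and a 48-fold higher number (1.68 log units; beyond the scatter) from compound 2 to compound 4; the limit leaves it open whether they differ. The true size of the step on the core of compound 1 stays hidden, as compound 3 gives only a limit: the limit of > 20000 nM in this assay, at which 1 of the 4 values shown sits.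

The change swaps oxygen for sulfur and also moves the point of attachment on the ring, and the compounds shown do not tell these two apart. Thiophen-3-yl and furan-2-yl on these cores would separate them.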